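Inverting one stereocentre of compound 1

The source may hold more compounds than are shown below. What is called first, only, known or untested is meant among the compounds shown, and "the series" means these compounds.

- compound 1 `COc1cc([C@@H]2C[C@]2(CO)C(=O)Nc2ccccc2Cl)cc(OC)c1OC` gives 13200 nM
- compound 2 `COc1cc([C@@H]2C[C@]2(CO)C(=O)NCc2ccc(C)cc2)cc(OC)c1OC` gives 26800 nM

In a functional assay on SW480 cells (Homo sapiens) for cytotoxicity, read by MTT assay, with a stated time of 48 h (a lower number here means a stronger inhibitor, a higher number a weaker inhibitor), compound 1 holds the lower of the two numbers (13200 nM). Compound 3 `COc1cc([C@@H]2C[C@@]2(CO)C(=O)Nc2ccccc2Cl)cc(OC)c1OC` has the same atoms and bonds as compound 1 (the two compounds have the same atoms and bonds and differ only in configuration as drawn: 1 of 2 stereo elements differ; a stereocentre at a saturated ring carbon is drawn S in compound 1 and R in compound 3): a stereocentre at a saturated ring carbon is drawn S in compound 1 and R in compound 3. Among the compounds with values here, the one measured step, a 2.0-fold higher number from compound 1 to compound 2 (0.31 log units; beyond the scatter), changes the amide substituent and leaves configuration untouched, so it offers only a rough scale. Within the data shown here, no measured pair tests configuration. A modest rise in the number is tentatively expected, and the direction remains uncertain. The estimated change is a 1.5-fold higher number from compound 1 to compound 3 (0.18 log units; within the scatter). Compound 3 is expected at 20000 nM (range 6500 nM to 60000 nM).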

Compound 3, half-maximal inhibitory concentration: 10700 nM
For compound 3 the middle estimate is 1.9-fold (0.27 log units) above the measured one; measured number inside the range.
By their numbers in this assay, from the lowest: compounds 3 and 1 (each within the scatter of the next); then compound 2.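

In this assay, the S to R inversion at this saturated ring carbon gives a 1.2-fold lower number from compound 1 to compound 3 (0.09 log units; within the scatter), so with the 2-chlorophenyl amide this stereocentre shows no configuration preference beyond the scatter. Within the data shown here, this is the first reading on configuration, as the earlier step changed only the amide substituent. The comparison isolates configuration alone: the fact that compounds 1 and 3 differ only in the configuration as drawn

Still open, on these data alone, is whether the inversion behaves the same way with the 4-methylbenzyl amide of compound 2, and what the second stereo element contributes. Also open, as far as these compounds go, is how an amine or a carboxylic acid in place of the hydroxymethyl group would read in this assay.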